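The source may hold more compounds than are shown below. What is called first, only, known or untested is meant among the compounds shown, and "the series" means these compounds.

Working notes on the series.

Compound 1 `Cc1ccc(N2CCN(C(=O)[C@@H]3[C@@H](c4ccc(Cl)cc4)CCN3C(=O)OC(C)C)CC2)c([C@@H](N)C(C)C)c1` is the reference point. In an assay on HEK293 cells for displacement of a labelled ligand from Melanocortin receptor 4 (Homo sapiens) (a lower number here means a stronger inhibitor, a higher number a weaker inhibitor), compound 1 gives 68 nM, the lowest of the three numbers on hand. Compound 3 `CCOC(=O)N1CC[C@@H](c2ccc(Cl)cc2)[C@H]1C(=O)N1CCN(c2ccc(C)cc2[C@@H](N)C(C)C)CC1` gives 130 nM in this assay, a gap to compound 1 that lies within the usual scatter, so the two are not told apart by these numbers. Compound 2 `CC(C)C[C@H](N)c1cc(C(F)(F)F)ccc1N1CCN(C(=O)C2(Cc3ccc(Cl)cc3)COC(=O)N2)CC1` gives 550 nM in this assay, and that gap to compound 1 lies beyond the scatter.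

Compound 4 `CCCC(=O)N1CC[C@H](c2ccc(Cl)cc2)[C@H]1C(=O)N1CCN(c2ccc(C)cc2[C@@H](N)C(C)C)CC1` has not yet been measured. It differs from compound 1 in one place: propyl in place of isopropoxy on a carbonyl carbon. Among the compounds with values here, no pair among the measured compounds isolates this change, so no measured step can be put beside it. What the set does show is that compound 1 and compound 3, which differ only in the group on this same carbonyl carbon, sit within scatter of each other in this assay. On that footing the step from compound 1 to compound 4 is expected to be small, a 1.5-fold higher number from compound 1 to compound 4 (0.17 log units; within the scatter), most likely not beyond the scatter, with a slight lean toward a higher number. For compound 4 in this assay the estimate is 100 nM, with a range from 40 nM to 300 nM.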

Compound 4, inhibition constant: 52 nM
The estimate for compound 4 lay 1.9-fold (0.28 log units) above the measured number; measured number inside the range.
By their numbers in this assay, from the lowest: compounds 4, 1 and 3 (each within the scatter of the next, the first and the last beyond it); then compound 2.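

Propyl in place of isopropoxy on a carbonyl carbon gives a 1.3-fold lower number from compound 1 to compound 4 (0.12 log units; within the scatter) in this assay, the first direct reading of this change in the series. The step removes the oxygen of isopropoxy, and with it the hydrogen-bond acceptor counted for that group, yet the two compounds are not told apart, so at this position in this assay that oxygen is not needed to keep a number in the range of compound 1. No measurement on hand explains why the step is so small.

On these data alone, whether an amine, a carboxylic acid or a longer chain such as hexyl on this carbonyl carbon would also stay within the scatter of compound 1 remains open. The compounds shown also do not test this change on the core of compound 2.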